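Cytotoxicity of Three Measured Analogues and One Proposed

A few compounds are considered here, and "the series" means these few. Any claim that something is new, unique, unknown or untested is made for them only; others in the source may bear on it.

Compound 1 `Clc1ccc(-c2nn(-c3ccccc3)cc2-c2nc3cc(Br)ccc3[nH]2)cc1` gives > 50000 nM in an ADME assay on HaCaT cells (Homo sapiens) for cytotoxicity, read by MTT assay, with a stated time of 48 h (a higher number here means a weaker inhibitor, a lower number a stronger inhibitor), a limit of the assay.
Compound 2 `COc1ccc2[nH]c(-c3cn(-c4ccccc4)nc3-c3ccc(Cl)cc3)nc2c1` gives > 50000 nM in this assay, a limit of the assay.
Compound 3 `COc1ccc(-c2nn(-c3ccccc3)cc2-c2nc3cc(Br)ccc3[nH]2)cc1` gives > 50000 nM in this assay, a limit of the assay.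

The change from compound 1 to compound 2 is methoxy in place of bromo on an aromatic carbon. Its step, a step that the two limits leave unreadable from compound 1 to compound 2, cannot be sized because of the limit of > 50000 nM in this assay, at which 3 of the 3 values shown sit. The cores of compound 1 and compound 3 differ by methoxy in place of chloro on an aromatic carbon, and the step that the two limits leave unreadable from compound 1 to compound 3 is likewise unreadable.

Compound 4 `COc1ccc(-c2nn(-c3ccccc3)cc2-c2nc3cc(OC)ccc3[nH]2)cc1` is not yet measured. It differs from compound 3 by methoxy in place of bromo on an aromatic carbon, the same change as from compound 1 to compound 2.

Compound 4 is expected to give a step that the limit leaves unreadable from compound 3 to compound 4 in this assay. That expectation rests on compound 3 giving > 50000 nM, a limit of the assay. It also rests on the observation that (the limit of > 50000 nM in this assay, at which 3 of the 3 values shown sit). The estimate for compound 4 is 80000 nM, between 35000 nM and 200000 nM.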

Compound 4, half-maximal inhibitory concentration: > 50000 nM
Compound 4: only a limit was reported; the forecaster's own chance of this, stated with the estimate: 85%; the middle value lies beyond the limit too.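

Compound 4 also sits at a limit, so neither its step from compound 3 nor its step from compound 2 can be read: the limit of > 50000 nM in this assay, at which 4 of the 4 values shown sit.

The compounds shown leave open whether methoxy in place of bromo or chloro changes cytotoxicity at all.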